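Replacing a dibromohydroxyphenyl group with a difluorophenyl group

The compounds below may be only part of what the source reports. "The series", "measured", "known", "first", "only" and "open" are said of these compounds alone.

Of the compounds shown here, three sharing one core have been measured in a functional assay on NCI-H460 cells (Homo sapiens) for cytotoxicity, read by MTT assay, with a stated time of 72 h; on this read-out lower numbers stand for stronger inhibition and higher numbers for weaker inhibition. Compound 1 `CN(C)CCn1cnnc1-c1cc(Oc2ccc(NC(=O)N/N=C/c3cc(C(C)(C)C)cc(C(C)(C)C)c3O)cc2F)ccn1` gives 590 nM. Compound 2 `CN(C)CCn1cnnc1-c1cc(Oc2ccc(NC(=O)N/N=C/c3cc(Br)c(O)c(Br)c3)cc2F)ccn1` gives 3760 nM, the second highest of the three numbers: compound 1 sits well below it, and compound 3 `Cn1cnnc1-c1cc(Oc2ccc(NC(=O)N/N=C/c3ccccc3)cc2F)ccn1`, which gives 15700 nM, sits above it, both gaps lying beyond the usual scatter.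

Compound 4 `CN(C)CCn1cnnc1-c1cc(Oc2ccc(NC(=O)N/N=C/c3ccc(F)cc3F)cc2F)ccn1` has not yet been measured. It differs from compound 2 in one place: 2,4-difluorophenyl in place of 3,5-dibromo-4-hydroxyphenyl on a carbon with a double bond to nitrogen. The group that enters carries no hydrogen-bond donor or acceptor, whereas the group that leaves carries one of each; compound 3, whose aromatic group likewise carries neither, gives the highest number of the three, though it also differs in another part of the molecule.

On that basis the step from compound 2 to compound 4 in this assay is expected to be upward and moderate, a 2.1-fold higher number from compound 2 to compound 4 (0.33 log units; beyond the scatter), beyond the scatter. Compound 4 is estimated at 8000 nM, within a range of 3000 nM to 25000 nM.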

Compound 4, half-maximal inhibitory concentration: 1930 nM
Estimate against measurement, compound 4: 4.1-fold (0.62 log units) above; the measured number lies below the stated range.
By their numbers in this assay, from the lowest: compound 1; then compounds 4 and 2 (each within the scatter of the next); then compound 3.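

In this assay, 2,4-difluorophenyl in place of 3,5-dibromo-4-hydroxyphenyl on a carbon with a double bond to nitrogen gives a 1.9-fold lower number from compound 2 to compound 4 (0.29 log units; within the scatter), so compound 2 and compound 4 cannot be told apart. This position therefore accepts a group with 0 hydrogen-bond donors and 0 hydrogen-bond acceptors, and with fluorine in place of bromine, without a shift beyond the scatter. Within the data shown here, no earlier pair could show this. None of them differed in one place only. Nothing measured here accounts for this result.

Still open, as far as these compounds go, is whether a different kind of group at this place, such as a phenyl ring carrying a carboxylic acid or an amine, would move the number beyond the scatter. Two substituted rings alone also cannot show how far this tolerance extends.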